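Aryl substitution pattern on the shared core: working notes

The source may report more compounds than this note shows. Statements on the series, on what has been measured and on what is new or still open speak of the compounds shown alone.

compound 1 `Oc1cccc(-c2cc(-c3cccc(F)c3)cc(-c3ccccc3O)n2)c1` — > 50000 nM (a limit)
compound 2 `Oc1cccc(-c2cc(-c3ccccc3C(F)(F)F)cc(-c3ccccc3O)n2)c1` — 16800 nM

In a functional assay on HeLa cells (Homo sapiens) for inhibition (a higher number here means a weaker inhibitor, a lower number a stronger inhibitor), compound 1 reaches only the limit of the assay, > 50000 nM. Compound 2 gives 16800 nM in this assay; this is the only number shown. The other value, that of compound 1, is a limit (the limit of > 50000 nM in this assay, at which 1 of the 2 values shown sits). Among the compounds with values here, the single measured step, an at least 2.9-fold lower number from compound 1 to compound 2 (0.47 log units; beyond the scatter), exchanges the aryl group at the same position. Within the data shown here, compound 3 `Oc1cccc(-c2cc(-c3ccc(C(F)(F)F)cc3)cc(-c3ccccc3O)n2)c1` differs from compound 2 by 4-(trifluoromethyl)phenyl in place of 2-(trifluoromethyl)phenyl on an aromatic carbon; no measured step shifts the trifluoromethyl group alone, so the direction is open. A step near the scatter is expected, a 1.1-fold lower number from compound 2 to compound 3 (0.05 log units; within the scatter). Compound 3 is estimated at 15000 nM, between 4000 nM and 60000 nM.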

Compound 3, half-maximal inhibitory concentration: > 50000 nM
Compound 3 ended at the assay's limit (the forecaster's own chance of this, stated with the estimate: 25%); middle value at least 3.3-fold (0.52 log units) from the limit.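

Moving the trifluoromethyl group around the phenyl ring, with the atoms unchanged, weakens inhibition in this assay: an at least 2.9-fold higher number from compound 2 to compound 3 (0.47 log units; beyond the scatter). At this position, then, the placement of the trifluoromethyl group on the phenyl ring matters and not only its presence, and compound 2 alone gives a number rather than a limit. The step between compound 1 and compound 3 cannot be read, as both values are limits: the limit of > 50000 nM in this assay, at which 2 of the 3 values shown sit.

Open, going by these compounds, is whether the gain with 2-(trifluoromethyl)phenyl carries over to a phenyl ring bearing an amine or a carboxylic acid in place of trifluoromethyl.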